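From methoxyamino to azido on a shared core

A few compounds are considered here, and "the series" means these few. Any claim that something is new, unique, unknown or untested is made for them only; others in the source may bear on it.

In an ADME assay on CCRF-CEM cells (Homo sapiens) for cytotoxicity, read by trypan blue exclusion, with a stated time of 6 days (a higher number here means that more compound is tolerated, a lower number that less compound is tolerated), compound 1 (`C[C@@]1(O)[C@H](O)[C@@H](CO)O[C@H]1n1cnc2c(ONC(=O)OCc3ccccc3)nc(N)nc21`) gives > 100000 nM and this is a limit, not a number. Compound 2 (`CONc1nc(N)nc2c1ncn2[C@@H]1O[C@H](CO)[C@@H](O)[C@@]1(C)O`) gives > 100000 nM and this too is only a limit. Compound 2 thus stands at the limit of > 100000 nM in this assay, at which 2 of the 2 values shown sit, and cannot be ranked any further. Compound 3 (`C[C@@]1(O)[C@H](O)[C@@H](CO)O[C@H]1n1cnc2c(N=[N+]=[N-])nc(N)nc21`) has azido in place of methoxyamino on an aromatic carbon. For the measured compounds named here, no measured step yet shows how far one change moves this assay, so the expected change is none beyond the usual scatter (a number no higher from compound 2 to compound 3 (the limit leaves the size open)). For compound 3 the estimated value is 100000 nM (expected range 30000 nM to 100000 nM).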

Compound 3, half-maximal cytotoxic concentration: > 100000 nM
Compound 3 ended at the assay's limit; the forecaster's own chance of this, stated with the estimate: 75%; the middle value lies on the limit itself.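

No size of change can be read between compound 2 and compound 3, because both rest at the same limit: the limit of > 100000 nM in this assay, at which 3 of the 3 values shown sit.

The compounds shown leave open whether any change on the shared core lowers the tolerated concentration in this assay, and by how much.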